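A few compounds are considered here, and "the series" means these few. Any claim that something is new, unique, unknown or untested is made for them only; others in the source may bear on it.

Measured compounds in a functional assay on MKN-45 cells (Homo sapiens) for inhibition, read by MTT assay, with a stated time of 72 h; a lower number here means a stronger inhibitor, a higher number a weaker inhibitor:
Compound 1 `COc1cc2c(Oc3ccc(NC(=O)c4nn(-c5ccccc5)c(=O)cc4C)cc3F)ccnc2cc1OCCCN1CCN(C)CC1` gives 130 nM.
Compound 2 `COc1cc2c(Oc3ccc(NC(=O)c4nn(-c5ccccc5C)c(=O)cc4C)cc3F)ccnc2cc1OCCCN1CCCC1` gives 760 nM.
Compound 3 `COc1cc2c(Oc3ccc(NC(=O)c4nn(-c5ccccc5C)c(=O)cc4C)cc3F)ccnc2cc1OCCCN1CCC(C)CC1` gives 1290 nM.

Among these three numbers compound 3 has the highest one, that is, the weakest inhibition; its nearest neighbour is compound 2, within the scatter, while compound 1 sits beyond the scatter from it.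

Compound 4 `COc1cc2c(Oc3ccc(NC(=O)c4nn(-c5ccccc5C)c(=O)cc4C)cc3F)ccnc2cc1OCCCN1CCN(C)CC1` is not yet measured. It arises from compound 3 by the change (4-methylpiperazin-1-yl in place of 4-methylpiperidin-1-yl on a saturated chain carbon, three bonds along the chain from an oxygen on an aromatic ring).

Going by the values given here, only one measured step touches the same position: a 1.7-fold higher number from compound 2 to compound 3 (0.23 log units; within the scatter), and that step lies within the scatter. Compound 1 carries the same 4-methylpiperazin-1-yl group that enters in compound 4, but it differs from compound 3 in more than one place, so its number can only hint that this group is compatible with strong inhibition. The exchange of one ring for another of the same size at the chain end gave no step beyond the scatter before, so the expected movement is small, with a modest lean toward a lower number because compound 1 gives 130 nM.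

Compound 4 is therefore estimated at 550 nM, within a range from 150 nM to 1800 nM, which is the expected step of a 2.3-fold lower number from compound 3 to compound 4 (0.37 log units; beyond the scatter) in this assay .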

Compound 4, half-maximal inhibitory concentration: 1630 nM
Compound 4: the middle estimate sits 3.0-fold (0.47 log units) below what was measured; the measured number falls inside the stated range.
By their numbers in this assay, from the lowest: compound 1; then compounds 2, 3 and 4 (each within the scatter of the next, the first and the last beyond it).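

In this assay, putting 4-methylpiperazin-1-yl in place of 4-methylpiperidin-1-yl at the chain end gives a 1.3-fold higher number from compound 3 to compound 4 (0.10 log units; within the scatter), so this exchange of one six-membered ring for the other barely registers, and carrying the group found in compound 1 does not by itself give a low number. Set against pyrrolidin-1-yl at the same place, the same group gives a 2.1-fold higher number from compound 2 to compound 4 (0.33 log units; beyond the scatter), a modest step and the only one among these chain ends that lies beyond the scatter. Going by these compounds alone, the large difference lies elsewhere: methyl in place of hydrogen on an aromatic carbon gives a 13-fold higher number from compound 1 to compound 4 (1.10 log units; beyond the scatter), and this pair now ties the gap to that single change, which the earlier compounds, differing in more than one place, could not do.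

Nothing at hand explains why that methyl matters so much. Still open, going by these compounds, is whether removing the methyl helps equally with pyrrolidin-1-yl or 4-methylpiperidin-1-yl at the chain end, and how a fluorine or chlorine on that aromatic carbon, or a morpholine at the chain end, would compare.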